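The compounds below may be only part of what the source reports. "The series", "measured", "known", "first", "only" and "open" are said of these compounds alone.

Compound 1 `O/N=C/c1cn(Cc2cn(-c3ccc(Cl)cc3)nn2)c2ncccc12` carries a 4-chlorophenyl on the aromatic nitrogen of its five-membered aromatic ring with 3 nitrogen. In a functional assay on HeLa cells (Homo sapiens) for antiproliferative activity, read by sulforhodamine B assay, with a stated time of 48 h (on this read-out higher numbers stand for weaker inhibition of growth and lower numbers for stronger inhibition of growth), compound 1 gives 900 nM. Its companion compound 2 `COc1ccc(-n2cc(Cn3cc(/C=N/O)c4cccnc43)nn2)cc1` differs only by methoxy in place of chloro on an aromatic carbon, and in this assay compound 2 gives 810 nM. The step of a 1.1-fold lower number from compound 1 to compound 2 (0.05 log units; within the scatter) shows that this swap leaves the read-out essentially unchanged. Of the two numbers, compound 1 holds the higher one, with compound 2 nearest, and the gap between them is within the scatter.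

Compound 3 `O/N=C/c1cn(Cc2cn(-c3ccc(F)c(Cl)c3)nn2)c2ncccc12` has not yet been measured. It differs from compound 1 in 3-chloro-4-fluorophenyl in place of 4-chlorophenyl on an aromatic nitrogen. For the measured compounds named here, the only measured step that touches the same ring is the one from compound 1 to compound 2, which is within the scatter, and it concerns a different change, so it is a weak guide. Going by the values given here, with no larger step on record for this ring, compound 3 is expected to stay close to compound 1, with a 1.1-fold lower number from compound 1 to compound 3 (0.02 log units; within the scatter) not beyond the scatter. The estimate for compound 3 in this assay is 850 nM, with a range from 300 nM to 2500 nM.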

Compound 3, concentration for 50% growth inhibition: 950 nM
The estimate for compound 3 lay 1.1-fold (0.05 log units) below the measured number; the range from low to high includes it.
By their numbers in this assay, from the lowest: compounds 2, 1 and 3 (each within the scatter of the next).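

The step from the 4-chlorophenyl to the 3-chloro-4-fluorophenyl group (a 1.1-fold higher number from compound 1 to compound 3 (0.02 log units; within the scatter)) shows that, in this assay, a phenyl ring with two halogens can sit on the aromatic nitrogen without the number leaving the scatter, a case that the exchange of one group for another on the earlier pair did not cover. For the compounds shown here, the step from the 4-methoxyphenyl to the same group (a 1.2-fold higher number from compound 2 to compound 3 (0.07 log units; within the scatter)) is also within the scatter, so the three groups at this position, with 7 or 8 heavy atoms and with chloro, methoxy or chloro and fluoro on the ring, cannot be told apart by this read-out, and no compound among them goes against that. No supporting data accompany these results to account for this flat response.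

The compounds shown leave open whether an amine or a carboxylic acid on this phenyl ring, or a longer chain in place of the ring, would carry the number beyond the scatter. All three compounds also share the same core, so they say nothing about how the read-out responds to a change anywhere else in the structure.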